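Removing the Amino Group from a Fused Bicyclic Core

The source may report more compounds than this note shows. Statements on the series, on what has been measured and on what is new or still open speak of the compounds shown alone.

Compound 1 `Oc1c(C2=NC3(CN2)CN2CCC3CC2)oc2ccccc12` gives 55% in an assay on cell membranes from SH-SY5Y cells for displacement of a labelled ligand from Neuronal acetylcholine receptor; alpha3/beta4 (Homo sapiens), read by scintillation counting, with a stated time of 2 h, tested at 5 uM; on this read-out higher numbers stand for more inhibition at the one concentration tested (going by the name of the read-out) and lower numbers for less inhibition. Compound 2 `Nc1c(C2=NC3(CN2)CN2CCC3CC2)oc2ccccc12` carries an amino group where compound 1 has a hydroxy group; in this assay compound 2 gives 47%. Compound 2 thus stands at the bottom of the two numbers measured, but the step of a number 8 percentage points lower from compound 1 to compound 2 (within the scatter) lies within the scatter, so the two compounds cannot be separated on this read-out. Compound 3 `c1ccc2oc(C3=NC4(CN3)CN3CCC4CC3)cc2c1` has not yet been measured. It differs from compound 2 by hydrogen in place of amino on an aromatic carbon. Among the compounds with values here, only one measured step exists, and it bears loosely on this change: exchanging hydroxy for amino at this place left the read-out unchanged beyond the scatter. Within the data shown here, removing the group altogether is a different change, and no measured step matches it. A step of a number 5 percentage points lower from compound 2 to compound 3 (within the scatter) is therefore expected, most likely staying within the scatter. Compound 3 is estimated to give 42%, with a range from 22% to 62%.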

Compound 3, a percentage reported as inhibition, at one concentration (the size of the read-out at that concentration, not a potency): 13%
Beside the measured number, compound 3's estimate is 29 percentage points above it, and the stated range ends above it.
By their numbers in this assay, from the lowest: compound 3; then compounds 2 and 1 (each within the scatter of the next).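

This position on the five-membered aromatic ring turns out to matter for the read-out in this assay: hydrogen in place of amino gives a number 34 percentage points lower from compound 2 to compound 3 (beyond the scatter) and hydrogen in place of hydroxy gives a number 42 percentage points lower from compound 1 to compound 3 (beyond the scatter) (both on the same aromatic carbon). Compounds 1 and 2 showed only that exchanging one of these groups for the other left the read-out within the scatter, whereas compound 3 shows that either group goes with clearly more inhibition than hydrogen does at this place. No measurement at hand explains this loss of inhibition.

The compounds shown leave open whether the read-out depends on amino or hydroxy in particular or would hold up with other groups at this place. A methoxy group, a methyl group or a fluorine atom on this carbon would help to settle that.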